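This account rests on a few compounds, and the source may have more. Where it says the series, first, only, none or still open, it means among the compounds named here.

Among the compounds with values here, compound 2 `COc1cc(-c2cc(/C=C/C(=O)c3ccccc3)nc3cc(-c4ccccc4)nn23)cc(OC)c1OC` and compound 1 `COc1cc(-c2cc(C(=O)/C=C/c3ccc(Cl)cc3)nc3cc(-c4ccccc4)nn23)cc(OC)c1OC` are the two measured members. In a functional assay on MDA-MB-231 cells (Homo sapiens) for antiproliferative activity, read by MTT assay, with a stated time of 24 h (a lower number here means a stronger inhibitor, a higher number a weaker inhibitor), compound 2 gives 15800 nM, while compound 1 gives 21600 nM; the step of a 1.4-fold lower number from compound 1 to compound 2 (0.14 log units; within the scatter) leaves the two compounds indistinguishable, so compound 2 stands level with compound 1 rather than apart from it. Compound 3 `COc1ccc(-c2cc(/C=C/C(=O)c3ccccc3)nc3cc(-c4ccccc4)nn23)cc1` differs from compound 2 by 4-methoxyphenyl in place of 3,4,5-trimethoxyphenyl on an aromatic carbon. Within the data shown here, no measured step touches this position; the one measured step concerns the 2-benzoylethenyl side and was within the scatter. No step beyond the scatter is therefore expected, a 1.0-fold higher number from compound 2 to compound 3 (0.01 log units; within the scatter). Compound 3 is estimated at 16000 nM, range 5000 nM to 50000 nM.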

Compound 3, half-maximal inhibitory concentration: 9900 nM
Beside the measured number, compound 3's estimate is 1.6-fold (0.21 log units) above it; the measured number falls inside the stated range.
By their numbers in this assay, from the lowest: compounds 3, 2 and 1 (each within the scatter of the next, the first and the last beyond it).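

This position, on an aromatic carbon next to the ring nitrogen, now has its first reading: in this assay, 4-methoxyphenyl in place of 3,4,5-trimethoxyphenyl gives a 1.6-fold lower number from compound 2 to compound 3 (0.20 log units; within the scatter) and so stays within the scatter. The full 3,4,5-trimethoxyphenyl group is therefore not required to keep the number in this range, at least with the 2-benzoylethenyl side in place. No supporting data bear on this step. Still open, as far as these compounds go, is whether a 4-aminophenyl or 4-carboxyphenyl group here would move the number beyond the scatter. Also open, from the compounds shown here alone, is whether this near-silence holds with the (2-(4-chlorophenyl)ethenyl)carbonyl side of compound 1.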